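The source may report more compounds than this note shows. Statements on the series, on what has been measured and on what is new or still open speak of the compounds shown alone.

For the measured compounds named here, in a functional assay on P388 cells (Mus musculus) for cytotoxicity (on this read-out lower numbers stand for stronger inhibition and higher numbers for weaker inhibition), compound 1 (`O=C1c2cccc3c2c(cc2c4ccccc4sc32)C(=O)N1CN1CCNCC1`) gives 72400 nM as the higher of the two numbers so far. Compound 2 (`CN(C)CCCN1C(=O)c2cccc3c2c(cc2c4ccccc4oc32)C1=O`) stands at 170 nM with the gap beyond the scatter. Compound 3 (`CN(C)CCCN1C(=O)c2cccc3c2c(cc2c4ccccc4sc32)C1=O`) brings one change from compound 1 (2-(dimethylamino)ethyl in place of piperazin-1-yl on a saturated chain carbon bound to an amide-type nitrogen in a ring) with 2-(dimethylamino)ethyl in place of piperazin-1-yl on a saturated chain carbon bound to an amide-type nitrogen in a ring. That change gives 3-(dimethylamino)propyl, which compound 2 at 170 nM also bears. On that ground a large step to lower numbers is expected in this assay and estimated as a 480-fold lower number from compound 1 to compound 3 (2.68 log units; beyond the scatter) for this change. Compound 3 is expected at 150 nM with an estimated range of 40 nM to 600 nM as a working figure.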

Compound 3, half-maximal inhibitory concentration: 320 nM
Compound 3: middle estimate off by 2.1-fold (0.33 log units), on the low side, and the stated range covers the measured number.
By their numbers in this assay, from the lowest: compounds 2 and 3 (each within the scatter of the next); then compound 1.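

In this assay, the group on a saturated chain carbon bound to an amide-type nitrogen in a ring has a large effect on a shared core: 2-(dimethylamino)ethyl in place of piperazin-1-yl gives a 230-fold lower number from compound 1 to compound 3 (2.35 log units; beyond the scatter). With 3-(dimethylamino)propyl on both, compound 3 (320 nM) and compound 2 (170 nM) lie within the scatter of each other, though their cores differ. Nothing available explains the size of this step. Open, as far as these compounds go, is whether the ring or the chain length matters: a 4-methylpiperazin-1-yl group or a longer chain ending in dimethylamino would separate the two.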